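A few compounds are considered here, and "the series" means these few. Any claim that something is new, unique, unknown or untested is made for them only; others in the source may bear on it.

Measured in a functional assay on HL-60 cells (Homo sapiens) for cytotoxicity, read by CellTiter-Blue, with a stated time of 48 h; a higher number here means a weaker inhibitor, a lower number a stronger inhibitor:
compound 1 `COC(=O)CC1C(C(=O)OC)=C(N)Oc2ccc(-c3cc(OC)cc(OC)c3)cc21`: 2420 nM
compound 2 `CCOC(=O)CC1C(C(=O)OCC)=C(N)Oc2ccc(-c3ccccc3F)cc21`: 73000 nM

Compound 2, at 73000 nM, has the higher of the two numbers, and its gap to compound 1 lies beyond the scatter. The two compounds differ in more than one place, so the gap cannot be assigned to any single change.

Compound 3 `CCOC(=O)CC1C(C(=O)OCC)=C(N)Oc2ccc(-c3cccs3)cc21` has not yet been measured. It departs from compound 2 in one place: thiophen-2-yl in place of 2-fluorophenyl on an aromatic carbon. In words, thiophen-2-yl stands in place of 2-fluorophenyl on an aromatic carbon.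

Going by the values given here, no measured pair isolates a change at this position, so the expectation in this assay is loose. The only guide is that compound 1, at 2420 nM, shows a much lower number is possible among these two compounds, while compound 2 sits at the high end. A moderate move towards a lower number is therefore expected, only a little beyond the scatter. The estimated step is a 2.9-fold lower number from compound 2 to compound 3 (0.47 log units; beyond the scatter). The expected value for compound 3 is 25000 nM, with an estimated range of 6000 nM to 80000 nM.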

Compound 3, half-maximal inhibitory concentration: > 80000 nM
Compound 3: a limit, no number (the forecaster's own chance of this, stated with the estimate: 10%); at least 3.2-fold (0.50 log units) between middle value and limit.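

In this assay compound 3 gives > 80000 nM, which is a limit of the assay and not a number. Thiophen-2-yl in place of 2-fluorophenyl, on an aromatic carbon of the shared core, gives an at least 1.0-fold higher number from compound 2 to compound 3 (0.03 log units; that floor lies within the scatter), so this single change brings no move towards a lower number and this position now has a step of its own to read. That step is only a floor, and its true size cannot be read, since the values at this end of the series run into the limit of the assay: the limit of > 80000 nM in this assay, at which 1 of the 3 values shown sits.

As far as these compounds go, whether compound 3 lies close to compound 2 or far from it remains open, as does how much of the lower number of compound 1 comes from its aromatic group, since compound 1 differs from compound 2 in more than one place. Also open, from the compounds shown here alone, are how an amine or a carboxylic acid on this aromatic carbon would read, and how the ethyl esters compare with methyl esters when nothing else in the core changes.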